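Swapping a Neopentyl Chain for a Chlorophenyl Ring

The source may hold more compounds than are shown below. What is called first, only, known or untested is meant among the compounds shown, and "the series" means these compounds.

Among the compounds with values here, compound 2 `CC(C)(C)CCc1cnc(CCc2ccc(-c3ccccc3C(=O)O)cc2)[nH]1` gives the lowest of the two numbers so far in an in vitro functional assay on cells for agonist activity at Bombesin receptor subtype-3 (Homo sapiens), read by luminescence and calcium flux (on this read-out lower numbers stand for an effect already at smaller amounts and higher numbers for an effect only at larger amounts of compound), namely 39 nM. Compound 1 `O=C(O)c1ccccc1-c1ccc(CCc2ncc(CCC3CCCCC3)[nH]2)cc1` gives 642 nM, so there is a 16-fold lower number from compound 1 to compound 2 (1.22 log units; beyond the scatter). Compound 3 `O=C(O)c1ccccc1-c1ccc(CCc2ncc(Cc3cccc(Cl)c3)[nH]2)cc1` differs from compound 2 by 3-chlorophenyl in place of neopentyl on a saturated chain carbon bound to an aromatic carbon. Within the data shown here, only that one measured step touches the same chain, and it was large; no measured step exchanges a saturated group for an aromatic ring, so the direction is uncertain. Compound 3 is expected to need somewhat more compound than compound 2. The estimate for compound 3 is 200 nM, ranging from 40 nM to 1000 nM, which means an expected step of a 5.1-fold higher number from compound 2 to compound 3 (0.71 log units; beyond the scatter).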

Compound 3, half-maximal effective concentration: 825 nM
Estimate against measurement, compound 3: 4.1-fold (0.62 log units) below; the range from low to high includes it.
By their numbers in this assay, from the lowest: compound 2; then compounds 1 and 3 (each within the scatter of the next).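

With 3-chlorophenyl at this place the result is a 21-fold higher number from compound 2 to compound 3 (1.33 log units; beyond the scatter) and the low number of the neopentyl compound is lost. The other comparison gives a 1.3-fold higher number from compound 1 to compound 3 (0.11 log units; within the scatter) so 3-chlorophenyl and cyclohexylmethyl cannot be told apart on this read-out. Of the three groups, only neopentyl, the one without a ring, goes with the low number.

As far as these compounds go, whether the ring itself is what matters stays open, since an unsubstituted phenyl or a chain ending in an amine could read either way. No evidence at hand explains the result.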